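The source may hold more compounds than are shown below. What is called first, only, known or untested is meant among the compounds shown, and "the series" means these compounds.

Working notes on the series. In a functional assay on the whole organism for inhibition, with Scenedesmus acutus as the target (on this read-out higher numbers stand for weaker inhibition and lower numbers for stronger inhibition), compound 1 (`COC(=O)c1cc(N2C(=O)C3=C(CCCC3)C2=O)ccc1Cl`) gives 1780 nM and compound 2 (`CCCOC(=O)c1cc(N2C(=O)C3=C(CCCC3)C2=O)ccc1Cl`) gives 1120 nM. For the measured compounds named here, compound 2 therefore stands within the scatter of the only other measured value, and the two cannot be ranked. The next compound is compound 3 (`CC(C)OC(=O)c1cc(N2C(=O)C3=C(CCCC3)C2=O)ccc1Cl`), which differs from compound 2 as follows: isopropyl in place of propyl on an oxygen next to a carbonyl group. In words, isopropyl takes the place of propyl on an oxygen next to a carbonyl group. Going by the values given here, only one measured step bears on this, and it is indirect: a 1.6-fold lower number from compound 1 to compound 2 (0.20 log units; within the scatter). Among the compounds with values here, no compound carrying isopropyl has yet been measured, so the data favour no direction. No step beyond the scatter is expected in this assay. The expected step is a 1.2-fold higher number from compound 2 to compound 3 (0.06 log units; within the scatter). For compound 3 the estimated value is 1300 nM, with an expected range of 600 nM to 2800 nM.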

Compound 3, half-maximal inhibitory concentration: 1230 nM
The estimate for compound 3 lay 1.1-fold (0.02 log units) above the measured number; the range from low to high includes it.
By their numbers in this assay, from the lowest: compounds 2, 3 and 1 (each within the scatter of the next).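

Within this assay, the new result shows that the arrangement of the three carbons in the chain on this oxygen does not separate the compounds: isopropyl in place of propyl gives a step within the scatter (a 1.1-fold higher number from compound 2 to compound 3 (0.04 log units; within the scatter)). Isopropyl in place of methyl on the same oxygen also stays within the scatter (a 1.4-fold lower number from compound 1 to compound 3 (0.16 log units; within the scatter)), so the methyl, propyl and isopropyl esters cannot be ranked at this position. Nothing at hand bears on the reason for this result.

Still open, from the compounds shown here alone, is whether a longer chain such as butyl or hexyl, or a ring such as benzyl, on this oxygen would give a step beyond the scatter. Going by these compounds, it is also open how a free carboxylic acid or an amide in place of the ester would read out.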